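Triazole aryl swap on a naphthoquinone: cytotoxicity outlook

The source may report more compounds than this note shows. Statements on the series, on what has been measured and on what is new or still open speak of the compounds shown alone.

Measured compounds:
compound 1 `CC(C)=CCC1=C(OCc2cn(-c3cccnc3)nn2)C(=O)c2ccccc2C1=O` — 1030000 nM
compound 2 `CC(C)=CCC1=C(OCc2cn(-c3ccc(Cl)cc3)nn2)C(=O)c2ccccc2C1=O` — 1150000 nM
compound 3 `CC(C)=CCC1=C(OCc2cn(-c3ccc(C#N)cc3)nn2)C(=O)c2ccccc2C1=O` — 707000 nM

In an ADME assay on HepG2 cells (Homo sapiens) for cytotoxicity, read by MTT assay, with a stated time of 24 h (on this read-out lower numbers stand for higher toxicity in this test and higher numbers for lower toxicity in this test), compound 3 gives 707000 nM. It stands within the scatter of both neighbours: a 1.5-fold lower number from compound 1 to compound 3 (0.16 log units; within the scatter) and a 1.6-fold lower number from compound 2 to compound 3 (0.21 log units; within the scatter). The unmeasured compound 4 `COc1ccc(-n2cc(COC3=C(CC=C(C)C)C(=O)c4ccccc4C3=O)nn2)c([N+](=O)[O-])c1` differs from compound 3 in one place: 4-methoxy-2-nitrophenyl in place of 4-cyanophenyl on an aromatic nitrogen. The two measured steps that bear on this position, a 1.5-fold lower number from compound 1 to compound 3 (0.16 log units; within the scatter) and a 1.6-fold lower number from compound 2 to compound 3 (0.21 log units; within the scatter), both change the group on the same aromatic nitrogen and both stay within the scatter, as does a 1.1-fold higher number from compound 1 to compound 2 (0.05 log units; within the scatter). Among the compounds with values here, no step in this assay beyond the scatter has therefore been seen for this position, and none is expected here either: a 1.2-fold higher number from compound 3 to compound 4 (0.08 log units; within the scatter). For compound 4 the expected value in this assay is 850000 nM, with a range from 350000 nM to 2000000 nM.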

Compound 4, half-maximal cytotoxic concentration: 532000 nM
Compound 4: middle estimate off by 1.6-fold (0.20 log units), on the high side; low and high end bracket the measured number.
By their numbers in this assay, from the lowest: compounds 4, 3, 1 and 2 (each within the scatter of the next, the first and the last beyond it).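

In this assay, within the data shown here, this position now shows a step beyond the scatter, though a modest one, which none of the earlier pairs showed (a 2.2-fold lower number from compound 2 to compound 4 (0.33 log units; beyond the scatter)). The change to 4-methoxy-2-nitrophenyl stays within the scatter against the other two groups (a 1.3-fold lower number from compound 3 to compound 4 (0.12 log units; within the scatter); a 1.9-fold lower number from compound 1 to compound 4 (0.29 log units; within the scatter)), so only the comparison with 4-chlorophenyl separates. Nothing available accounts for this step. The compounds shown leave open whether an amine or a carboxylic acid on the aryl ring would move the number further, and whether a longer chain in place of the prenyl-like side chain of the shared core would matter.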